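This account rests on a few compounds, and the source may have more. Where it says the series, first, only, none or still open, it means among the compounds named here.

Measured so far in a physicochemical assay for solubility, read by LC-MS, with a stated time of 24 h, at pH 6.5; a lower number here means a less soluble compound, a higher number a more soluble compound

- Compound 1 `CC[C@@H](Nc1c(C#N)c(-c2ccc(-c3cccc(Cl)c3F)cc2)nc2cnccc12)C(N)=O` gives < 0.1 ug/mL as a limit of the assay, not a number
- Compound 2 `CCOc1ccccc1-c1ccc(-c2nc3cnccc3c(N[C@H](CC)C(=O)O)c2C#N)cc1` gives 247 ug/mL as a measured number

For the measured compounds named here, compound 2 therefore holds the only actual number in this small set. Compound 3 `CC[C@@H](Nc1c(C#N)c(-c2ccc(-c3cccc(C)c3F)cc2)nc2cnccc12)C(=O)O` differs from compound 2 in one place, with 2-fluoro-3-methylphenyl in place of 2-ethoxyphenyl on an aromatic carbon as the change. Going by the values given here, no measured step shows what this swap does in this assay so the expectation is a judgement, anchored on compound 2 at 247 ug/mL and pointing to a moderate fall. The estimated size of a 2.5-fold lower number from compound 2 to compound 3 (0.39 log units; beyond the scatter) is a modest one, with little chance of reaching a limit. Compound 3 is estimated at 100 ug/mL with 20 ug/mL to 350 ug/mL as its expected range.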

Compound 3, solubility: > 1000 ug/mL
Compound 3 ended at the assay's limit; the forecaster's own chance of this, stated with the estimate: 3%; middle value at least 10-fold (1.00 log units) away from the limit.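

In this assay, for the compounds shown here, 2-fluoro-3-methylphenyl in place of 2-ethoxyphenyl gives an at least 4.0-fold higher number from compound 2 to compound 3 (0.60 log units; beyond the scatter), the first one-place step in this set, so the group on this aromatic carbon, para to a large group, can clearly move the read-out. The full size of that step cannot be read because compound 3 stands at a limit of the assay, not at a number: the limit of > 1000 ug/mL in this assay, at which 1 of the 3 values shown sits.

Still open, from the compounds shown here alone, is which part of the swap matters: the fluorine, the methyl or the removal of the ethoxy. Also open, going by these compounds, is how a ring carrying an amine would read at this position.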